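Benzylselanyl in Place of Methylsulfanyl on a Shared Core

The source may report more compounds than this note shows. Statements on the series, on what has been measured and on what is new or still open speak of the compounds shown alone.

Compound 1, `C[Se]/C(=N\C(=O)c1cnc2ccccc2c1)NC(=O)c1cnc2ccccc2c1`, gives > 100000 nM in a functional assay on HT-29 cells (Homo sapiens) for cytotoxicity, read by MTT assay, with a stated time of 72 h (on this read-out lower numbers stand for stronger inhibition of growth and higher numbers for weaker inhibition of growth), which is a limit of the assay and not a number.
Compound 2, `CS/C(=N\C(=O)c1cnc2ccccc2c1)NC(=O)c1cnc2ccccc2c1`, gives > 100000 nM in this assay, likewise a limit rather than a number.

Compound 2 therefore stands only at a limit, and all that is known of its place among the values shown is the limit of > 100000 nM in this assay, at which 2 of the 2 values shown sit. The step that the two limits leave unreadable from compound 1 to compound 2 exchanges one group for another on a carbon with a double bond to nitrogen, and with both of its ends at the limit its size cannot be read. Compound 3, `O=C(/N=C(/NC(=O)c1cnc2ccccc2c1)[Se]Cc1ccccc1)c1cnc2ccccc2c1`, differs from compound 2 by a group of 8 heavy atoms (7 carbon, 1 selenium; one six-membered aromatic ring of carbon only) in place of a group of 2 heavy atoms (1 carbon, 1 sulfur; no ring), on a carbon with a double bond to nitrogen. Among the measured compounds shown here, the single measured step touches the same carbon, and it left nothing readable; neither measured compound gives a number inside the range of this assay. Compound 3 is thus expected to sit again at or past the limit, a step that the limit leaves unreadable from compound 2 to compound 3 being the step this expectation means. The estimate for compound 3 is 150000 nM, with a range from 30000 nM to 1000000 nM.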

Compound 3, concentration for total growth inhibition: > 100000 nM
Compound 3: no number, only a limit; the forecaster's own chance of this, stated with the estimate: 80%; the middle value is on the limit's open side.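

In this assay, among the compounds shown here, compound 3 gives > 100000 nM as a limit of the assay and not a number, so no step among compound 1, compound 2 and compound 3 can be read. The compounds shown leave open whether any group on the carbon with a double bond to nitrogen brings growth inhibition inside the measurable range.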